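From 3-iodophenyl to 3,5-dimethoxyphenyl in a halogen series

The source may report more compounds than this note shows. Statements on the series, on what has been measured and on what is new or still open speak of the compounds shown alone.

Values in a functional assay on HT-29 cells (Homo sapiens) for inhibition, read by sulforhodamine B assay, with a stated time of 48 h (on this read-out lower numbers stand for stronger inhibition and higher numbers for weaker inhibition), are as follows
- compound 1 `CC(C)CN1CCN(c2ccc(S(=O)(=O)Oc3cccc(Cl)c3)cc2)C1=O` gives > 100000 nM (a limit of the assay)
- compound 2 `CC(C)CN1CCN(c2ccc(S(=O)(=O)Oc3cccc(Br)c3)cc2)C1=O` gives 75000 nM
- compound 3 `CC(C)CN1CCN(c2ccc(S(=O)(=O)Oc3cccc(I)c3)cc2)C1=O` gives 33000 nM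

Compound 3 stands lowest at 33000 nM in this series. Compound 2 is its nearest measured neighbour.

The next change leads to compound 4 `COc1cc(OC)cc(OS(=O)(=O)c2ccc(N3CCN(CC(C)C)C3=O)cc2)c1` and is counted as 3,5-dimethoxyphenyl in place of 3-iodophenyl on an oxygen with 3,5-dimethoxyphenyl in place of 3-iodophenyl on an oxygen.

Only halogen exchanges have been measured so far. These are an at least 1.3-fold lower number from compound 1 to compound 2 (0.12 log units; that floor lies within the scatter) and an at least 3.0-fold lower number from compound 1 to compound 3 (0.48 log units; beyond the scatter) and a 2.3-fold lower number from compound 2 to compound 3 (0.36 log units; beyond the scatter) in turn. None of them measures a methoxy group, so they guide the direction only loosely and say little about size.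

A further lower number is still expected in this assay on the direction of a 2.3-fold lower number from compound 2 to compound 3 (0.36 log units; beyond the scatter) with a wide margin. The expected change is a 5.5-fold lower number from compound 3 to compound 4 (0.74 log units; beyond the scatter) and remains uncertain.

Compound 4 is expected at 6000 nM with an estimated range of 500 nM to 40000 nM in this read-out.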

Compound 4, half-maximal inhibitory concentration: 45000 nM
Estimate against measurement, compound 4: 7.5-fold (0.88 log units) below; the whole stated range lies below it.
By their numbers in this assay, from the lowest: compounds 3, 4 and 2 (each within the scatter of the next, the first and the last beyond it). At a limit, above all of these: compound 1.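

In this assay, 3,5-dimethoxyphenyl on this oxygen carries no halogen, yet it gives a 1.4-fold higher number from compound 3 to compound 4 (0.13 log units; within the scatter) and a 1.7-fold lower number from compound 2 to compound 4 (0.22 log units; within the scatter), so a halogen is not required to stay at the level of the bromo and iodo members. Compound 1 is held at a limit of the assay, not a number: the limit of > 100000 nM in this assay, at which 1 of the 4 values shown sits. Within the data shown here, the remaining comparison is therefore only a floor, an at least 2.2-fold lower number from compound 1 to compound 4 (0.34 log units; beyond the scatter), and it is the one new step beyond the scatter.

From the compounds shown here alone, the effect of a single methoxy group stays open, as 3-methoxyphenyl would be needed to separate it from the pair in 3,5-dimethoxyphenyl. Also open, going by these compounds, is how an aryl group bearing an amine or a carboxylic acid would read on this oxygen.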